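The source may hold more compounds than are shown below. What is called first, only, known or untested is meant among the compounds shown, and "the series" means these compounds.

In a physicochemical assay for solubility, read by nephelometry, measured as kinetic solubility, at pH 2 (a higher number here means a more soluble compound, a lower number a less soluble compound), compound 2 (`Cc1cc(-n2cccn2)cc(C(=O)NNS(=O)(=O)c2ccccc2)c1F`) reads 6.3 ug/mL and compound 3 (`Cc1cc(C(=O)NNS(=O)(=O)c2ccccc2F)cc(-c2ccco2)c1`) stands level with it at 6.3 ug/mL while compound 1 (`Cc1cc(-c2ncccn2)cc(C(=O)NNS(=O)(=O)c2ccccc2)c1F`) reads 50 ug/mL on this scale. Compound 4 (`Cc1cc(-c2ccccn2)cc(C(=O)NNS(=O)(=O)c2ccccc2)c1F`) is not yet measured and carries pyridin-2-yl in place of 1H-pyrazol-1-yl on an aromatic carbon para to a fluoro group. Among the measured compounds shown here, one measured step bears on this change, the swap of pyrimidin-2-yl for 1H-pyrazol-1-yl, which gave a 7.9-fold lower number from compound 1 to compound 2 (0.90 log units; beyond the scatter) and is modest in size. Compound 4 regains a six-membered aromatic ring, though with one nitrogen fewer than compound 1. An upward step a 4.0-fold higher number from compound 2 to compound 4 (0.60 log units; beyond the scatter) is therefore expected in this assay and it should be smaller than the measured one. For compound 4 the estimated value is 25 ug/mL with an expected range from 9 ug/mL to 60 ug/mL in this measure.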

Compound 4, solubility: 50 ug/mL
Compound 4: middle estimate off by 2.0-fold (0.30 log units), on the low side, and the stated range covers the measured number.
By their numbers in this assay, from the lowest: compounds 2 and 3 (each within the scatter of the next); then compounds 1 and 4 (each within the scatter of the next).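

The a 7.9-fold higher number from compound 2 to compound 4 (0.90 log units; beyond the scatter) in this assay shows that the gain over 1H-pyrazol-1-yl at this position, para to a fluoro group, is not confined to pyrimidin-2-yl. Pyridin-2-yl in place of pyrimidin-2-yl gives no change at the digits printed from compound 1 to compound 4 (within the scatter) in the same assay, so the two six-membered aromatic rings cannot be told apart here, although only compounds 1, 2 and 4 support this comparison. Nothing measured here accounts for the step.
Going by these compounds, what a morpholine or a carboxylic acid would read at this position remains open, as does whether a phenyl ring would match the two nitrogen-bearing six-membered rings.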